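Exchanging the Aryl Group on the Ring Nitrogen

The source may report more compounds than this note shows. Statements on the series, on what has been measured and on what is new or still open speak of the compounds shown alone.

Compound 1 `CCOC(=O)c1c(-c2cc3ccccc3oc2=O)nn(-c2ccc(C)c(C)c2)c1C(=O)OCC`: 52000 nM
Compound 2 `CCOC(=O)c1c(-c2cc3ccccc3oc2=O)nn(-c2ccc(OC)cc2)c1C(=O)OCC`: 86000 nM

Both compounds were tested in a functional assay on A549 cells (Homo sapiens) for cytotoxicity, read by MTT assay, with a stated time of 48 h; on this read-out higher numbers stand for weaker inhibition and lower numbers for stronger inhibition. Compound 2 has the highest of the two numbers shown; its nearest neighbour is compound 1, and the step of a 1.7-fold higher number from compound 1 to compound 2 (0.22 log units; within the scatter) lies within the scatter. Compound 3 `CCOC(=O)c1c(-c2cc3ccccc3oc2=O)nn(-c2cccc(F)c2)c1C(=O)OCC` differs from compound 2 by 3-fluorophenyl in place of 4-methoxyphenyl on an aromatic nitrogen. Among the measured compounds shown here, the only measured step that bears on this change, a 1.7-fold higher number from compound 1 to compound 2 (0.22 log units; within the scatter), also exchanges the group on the aromatic nitrogen and stays within the scatter. Compound 3 is therefore expected to show no step beyond the scatter in this assay, an expected change of a 1.2-fold lower number from compound 2 to compound 3 (0.09 log units; within the scatter). For compound 3 the estimate is 70000 nM, with an expected range from 30000 nM to 170000 nM.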

Compound 3, half-maximal inhibitory concentration: 59000 nM
For compound 3 the middle estimate is 1.2-fold (0.07 log units) above the measured one; the measured number falls inside the stated range.
By their numbers in this assay, from the lowest: compounds 1, 3 and 2 (each within the scatter of the next).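

In this assay, 3-fluorophenyl in place of 4-methoxyphenyl on the aromatic nitrogen gives a 1.5-fold lower number from compound 2 to compound 3 (0.16 log units; within the scatter), and 3-fluorophenyl in place of 3,4-dimethylphenyl gives a 1.1-fold higher number from compound 1 to compound 3 (0.05 log units; within the scatter). Among the compounds shown here, a fluorine-bearing ring thus joins the two earlier aryl groups, and no step among the three leaves the scatter, so this position has not yet separated any of them. No measurement shown here explains this result.

Going by these compounds, whether an amine, a carboxylic acid or a longer chain in place of the aryl group on this nitrogen would move the number beyond the scatter remains open. So does the effect of exchanging either ethoxycarbonyl group on the shared core.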